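This account rests on a few compounds, and the source may have more. Where it says the series, first, only, none or still open, it means among the compounds named here.

Series notes, pendant aryl on the shared core.

Compound 2 `COc1cc(-n2cnc3ccc(-c4ccc([N+](=O)[O-])cc4)cc32)cc(OC)c1OC` is the reference point for this step. Among the compounds with values here, in a functional assay on SGC-7901 cells (Homo sapiens) for antiproliferative activity, read by MTT assay, with a stated time of 72 h (on this read-out higher numbers stand for weaker inhibition and lower numbers for stronger inhibition), compound 2 gives 79 nM, the second highest of the three numbers so far: compound 1 `COc1cc(-n2cnc3ccc(-c4cccc(N)c4)cc32)cc(OC)c1OC` gives 21 nM, and compound 3 `COc1cccc(-c2ccc3ncn(-c4cc(OC)c(OC)c(OC)c4)c3c2)c1` gives 3310 nM. Both neighbouring steps change only the pendant aryl: a 3.8-fold higher number from compound 1 to compound 2 (0.58 log units; beyond the scatter), and a 42-fold higher number from compound 2 to compound 3 (1.62 log units; beyond the scatter). The whole spread seen so far, a 160-fold higher number from compound 1 to compound 3 (2.20 log units; beyond the scatter), also comes from that ring alone.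

Compound 4 `COc1cc(-n2cnc3ccc(-c4cc(F)ccc4F)cc32)cc(OC)c1OC` carries 2,5-difluorophenyl in place of 4-nitrophenyl on an aromatic carbon. Within the data shown here, no measured step places a 2,5-difluorophenyl, or any ring without an acceptor, at this position, so the direction is not fixed by precedent; what is established is that exchanges on this ring have moved the number in this assay by modest to large amounts, never within the scatter. A change beyond the scatter is therefore expected, with a wide range. Compound 4 is estimated at 250 nM (range 40 nM to 1600 nM), meaning an expected step of a 3.2-fold higher number from compound 2 to compound 4 (0.50 log units; beyond the scatter).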

Compound 4, half-maximal inhibitory concentration: 6590 nM
Estimate against measurement, compound 4: 26-fold (1.42 log units) below, and the stated range ends below it.
By their numbers in this assay, from the lowest: compound 1; then compound 2; then compounds 3 and 4 (each within the scatter of the next).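

In this assay, the exchange for 2,5-difluorophenyl gives the largest step yet away from the 4-nitrophenyl ring, an 83-fold higher number from compound 2 to compound 4 (1.92 log units; beyond the scatter), and extends the spread on this ring to a 310-fold higher number from compound 1 to compound 4 (2.50 log units; beyond the scatter). The step of a 2.0-fold higher number from compound 3 to compound 4 (0.30 log units; within the scatter) places two rings with different substituents level at the high end, so among these four compounds the low numbers belong only to the rings carrying a nitrogen group, 3-aminophenyl and 4-nitrophenyl. Nothing available here explains why the number rises so far with this ring.

From the compounds shown here alone, whether a nitrogen group as such keeps the number low remains open, and a nitrile or a dimethylamino group on this ring would test that. An unsubstituted phenyl would show whether the fluorines matter at all.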